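Chloro Changes and Liver Cell Toxicity in One Series

A few compounds are considered here, and "the series" means these few. Any claim that something is new, unique, unknown or untested is made for them only; others in the source may bear on it.

Compound 1, `Cc1cc(NC(=O)Nc2ccc(C)c(Cl)c2)c2ccccc2n1`: > 25000 nM
Compound 2, `Cc1ccc(NC(=O)Nc2cc(C)nc3ccccc23)cc1`: > 25000 nM
Compound 3, `Cc1cc(NC(=O)Nc2ccc(Cl)cc2)c2ccccc2n1`: > 25000 nM

In an ADME assay on HepG2 cells (Homo sapiens) for cytotoxicity, with a stated time of 72 h (on this read-out higher numbers stand for an effect only at larger amounts of compound and lower numbers for an effect already at smaller amounts), compound 1 gives > 25000 nM, which is a limit of the assay and not a number. Compound 2 gives > 25000 nM, again a limit. Compound 3 gives > 25000 nM, also a limit. Because (the limit of > 25000 nM in this assay, at which 3 of the 3 values shown sit), the two steps out of compound 2 cannot be read: a step that the two limits leave unreadable from compound 2 to compound 1, made by chloro in place of hydrogen on an aromatic carbon, and a step that the two limits leave unreadable from compound 2 to compound 3, made by chloro in place of methyl on an aromatic carbon. Compound 4, `Cc1cc(NC(=O)Nc2ccc(Cl)cc2Cl)c2ccccc2n1`, is not yet measured; it differs from compound 3 by chloro in place of hydrogen on an aromatic carbon. This is the same kind of change as that from compound 2 to compound 1, though there the chloro enters ortho to a methyl group and meta to a large group, while here it enters ortho to a large group and meta to a chloro group. The step from compound 3 to compound 4 is expected to be a step that the limit leaves unreadable from compound 3 to compound 4, resting on compound 3 at > 25000 nM and on (the limit of > 25000 nM in this assay, at which 3 of the 3 values shown sit). Compound 4 is therefore expected to give 30000 nM, between 12000 nM and 80000 nM.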

Compound 4, half-maximal effective concentration: 16000 nM
Compound 4: the middle estimate sits 1.9-fold (0.27 log units) above what was measured; the measured number falls inside the stated range.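

In this assay, chloro in place of hydrogen on an aromatic carbon, here ortho to a large group and meta to a chloro group, gives an at least 1.5-fold lower number from compound 3 to compound 4 (0.19 log units; that floor lies within the scatter). The same kind of change leads from compound 2 to compound 1, but that step cannot be read, because both compounds sit at the limit of the assay: the limit of > 25000 nM in this assay, at which 3 of the 4 values shown sit. Going by these compounds alone, the result therefore shows that compound 4 alone has a measured number, but it gives no second readable step to set beside the first, and with its floor inside the scatter, it does not show that the change carries from one core to another.

The compounds shown leave open whether bromo, methoxy or an amine in place of this chloro would give a step beyond the scatter. They also leave open whether a longer chain in place of the methyl on the shared core would bring a number into view in this assay.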